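This account rests on a few compounds, and the source may have more. Where it says the series, first, only, none or still open, it means among the compounds named here.

Of the compounds shown here, three have been measured in a functional assay (Saphenous vein) with Canis familiaris (Canis lupus familiaris) as the target; on this read-out higher numbers stand for higher potency (the scale is a negative logarithm) and lower numbers for lower potency. Compound 1 `COc1ccc(NC(=O)c2ccc(-c3ccncc3)cc2)cc1N1CCN(C)CC1` gives 8 in this assay, compound 2 `COc1ccc(C(=O)Nc2ccc(-c3ccc(-c4noc(C)n4)cc3C)cc2)cc1N1CCN(C)CC1` gives 8.2, and compound 3 `COc1ccc(C(=O)Nc2ccc(-c3ccc(C=O)cc3C)cc2)cc1CCCN(C)C` gives 8.4. Compound 3 stands at the top of these three numbers, but compound 2 lies within the usual scatter of it, so the two cannot be told apart; only compound 1 lies beyond the scatter, below compound 3.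

Compound 4 `CCOc1ccc(NC(=O)c2ccc(OC)c(CCCN(C)C)c2)cc1` has not yet been measured in this assay. It differs from compound 3 in one place: ethoxy in place of 4-formyl-2-methylphenyl on an aromatic carbon. A group of nine heavy atoms with its own aromatic ring is thus replaced by a three-atom ethoxy on the same aromatic carbon, para to a large group.

Going by the values given here, no step between two measured compounds matches this change, so the expectation rests on the structures alone. Every measured compound carries a second aromatic ring at this place, and taking it away is a large cut into the molecule. The step from compound 3 to compound 4 is therefore expected to be a drop, estimated at a number 1.60 log units lower from compound 3 to compound 4 (beyond the scatter), well beyond the scatter. In this assay compound 4 is expected to give an estimated 6.8, with a likely range from 5.8 to 7.8.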

Compound 4, negative logarithm of the antagonist equilibrium constant: 6.9
For compound 4 the middle estimate is 0.10 log units below the measured one, and the stated range covers the measured number.
By their numbers in this assay, from the lowest: compound 4; then compounds 1, 2 and 3 (each within the scatter of the next, the first and the last beyond it).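

Until now, every compound shown carried a second aromatic ring at this place, so nothing showed how much that ring counts. In this assay the exchange of 4-formyl-2-methylphenyl for ethoxy on this aromatic carbon gives a number 1.50 log units lower from compound 3 to compound 4 (beyond the scatter) as a large step, so potency here depends strongly on what this carbon carries, although compound 4 still gives 6.9 without the ring. Nothing available bears on why the step is this large, so it stands as an observation without an explanation.

The change takes away the aromatic ring, its formyl group and its methyl group all at once, and it also shortens the substituent, so the compounds shown cannot say which of these parts accounts for the step. A plain phenyl ring or a 2-methylphenyl ring without the formyl group would separate the ring from its substituents on this carbon, and a longer chain such as butoxy would show whether length alone recovers any of the potency.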